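Removing One Methoxy Group from Compound 3

The compounds below may be only part of what the source reports. "The series", "measured", "known", "first", "only" and "open" are said of these compounds alone.

Compound 3 `COc1ccc(C(=O)/C=C/c2cc(-c3cc(OC)c(OC)c(OC)c3)n[nH]2)cc1OC` carries a 3,4-dimethoxyphenyl group on its carbonyl carbon. In a functional assay on SF-268 cells (Homo sapiens) for inhibition, read by sulforhodamine B assay, with a stated time of 48 h (on this read-out lower numbers stand for higher toxicity in this test and higher numbers for lower toxicity in this test), compound 3 gives 8590 nM. Compound 1 `COc1cc(-c2cc(/C=C/C(=O)c3ccc(N)cc3)[nH]n2)cc(OC)c1OC`, with a 4-aminophenyl group in that position, gives 9160 nM; the two values sit within the scatter of each other, as a 1.1-fold lower number from compound 1 to compound 3 (0.03 log units; within the scatter) shows. Compound 2 `COc1cc(-c2cc(/C=C/C(=O)c3ccc(Cl)c(Cl)c3)[nH]n2)cc(OC)c1OC`, bearing a 3,4-dichlorophenyl group, gives only a limit, > 100000 nM, namely (the limit of > 100000 nM in this assay, at which 1 of the 3 values shown sits). The two large measured steps both involve this limit: an at least 10-fold higher number from compound 1 to compound 2 (1.03 log units; beyond the scatter) and an at least 11-fold lower number from compound 2 to compound 3 (1.06 log units; beyond the scatter).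

Compound 4 `COc1ccc(C(=O)/C=C/c2cc(-c3cc(OC)c(OC)c(OC)c3)n[nH]2)cc1` differs from compound 3 by hydrogen in place of methoxy on an aromatic carbon. Among the compounds with values here, none of the measured steps removes a single methoxy group from an otherwise unchanged aryl group; each of them exchanges the whole aryl group on the carbonyl carbon. What the measured compounds do show is that 4-aminophenyl and 3,4-dimethoxyphenyl give numbers within the scatter of each other, so the read-out in this assay tolerates different substitution on that ring, while only the dichloro pattern reached the limit. A 4-methoxyphenyl group is therefore expected to give a number close to that of compound 3, a step no larger than the scatter, perhaps slightly upward.

The step from compound 3 to compound 4 is expected to be a 1.4-fold higher number from compound 3 to compound 4 (0.15 log units; within the scatter). Compound 4 is estimated at 12000 nM, within a range from 5000 nM to 35000 nM.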

Compound 4, concentration lethal to 50% of the cells: > 100000 nM
Compound 4 gave a limit, no number; the forecaster's own chance of this, stated with the estimate: 10%; middle value at least 8.3-fold (0.92 log units) away from the limit.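

The earlier compounds shown here exchanged the whole aryl group on the carbonyl carbon, whereas this change touches a single substituent, and in this assay it gives an at least 11-fold higher number from compound 3 to compound 4 (1.06 log units; beyond the scatter) with nothing else altered. Compound 1 and compound 3 had sat within the scatter of each other, yet an at least 10-fold higher number from compound 1 to compound 4 (1.03 log units; beyond the scatter) appears with methoxy in place of amino, so the tolerance of this ring for different substitution seen in that earlier pair does not extend to the 4-methoxyphenyl group. Compound 4 gives a limit and not a number, as compound 2 does, so the step between these two cannot be read: the limit of > 100000 nM in this assay, at which 2 of the 4 values shown sit.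

The compounds shown leave open whether a hydroxy group, a fluorine atom or an amine in place of the methoxy group that left would return a number close to that of compound 3. They also leave open whether removing the other methoxy group instead, or replacing it with an ethoxy group, would give a result like that of compound 3 or like that of compound 4.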